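A methoxy for fluoro exchange at the assay limit

The source may report more compounds than this note shows. Statements on the series, on what has been measured and on what is new or still open speak of the compounds shown alone.

compound 1 `CCCCNc1ccnc2cc(F)ccc12`: in a functional assay on 184B5 cells (Homo sapiens) for cytotoxicity, read by sulforhodamine B assay, with a stated time of 48 h, in the presence of a further agent that is not named here (on this read-out higher numbers stand for weaker inhibition of growth and lower numbers for stronger inhibition of growth), compound 1 gives 12400 nM
compound 2 `CN(C)CCNc1ccnc2cc(Cl)ccc12`: in this assay compound 2 gives > 20000 nM, a limit
compound 3 `CN(C)CCNc1ccnc2cc(F)ccc12`: in this assay compound 3 gives > 20000 nM, a limit

Compound 3 thus sits at the limit of > 20000 nM in this assay, at which 2 of the 3 values shown sit. The step of an at least 1.6-fold higher number from compound 1 to compound 3 (0.20 log units; that floor lies within the scatter) has a floor that the scatter covers, and the step that the two limits leave unreadable from compound 2 to compound 3 cannot be read. Compound 4 `COc1ccc2c(NCCN(C)C)ccnc2c1` differs from compound 3 by methoxy in place of fluoro on an aromatic carbon. Within the data shown here, no measured step touches this exchange, so nothing points to a move beyond the scatter in this assay. The step that the limit leaves unreadable from compound 3 to compound 4 is therefore expected to be small, in no clear direction. Compound 4 is estimated at 25000 nM, within 8000 nM to 80000 nM, and will most likely again be reported as a limit.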

Compound 4, concentration for 50% growth inhibition: > 20000 nM
Compound 4 was reported as a limit; the forecaster's own chance of this, stated with the estimate: 70%; the middle value does not contradict the limit.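

In this assay compound 4 gives > 20000 nM, a limit, so its steps to compound 2 and compound 3 cannot be read. Whether chloro, fluoro and methoxy on that aromatic carbon differ at all in growth inhibition stays open, because compound 2, compound 3 and compound 4 share one limit: the limit of > 20000 nM in this assay, at which 3 of the 4 values shown sit.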